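Flipping the Double Bond Geometry in Compound 3

The source may report more compounds than this note shows. Statements on the series, on what has been measured and on what is new or still open speak of the compounds shown alone.

Three compounds have so far been measured in an assay (Equus caballus) for inhibition of Thromboxane-A synthase (Homo sapiens), using microsomes; on this read-out higher numbers stand for weaker inhibition and lower numbers for stronger inhibition:

Compound 1 `C=C(C)C(CCC/C=C(\c1ccccc1)c1cccnc1)C(=O)O`: 28 nM
Compound 2 `CC(C)(CCC/C=C(\c1ccccc1)c1cccnc1)C(=O)O`: 21 nM
Compound 3 `CC(C)(CCCC/C=C(/c1ccccc1)c1cccnc1)C(=O)O`: 38 nM

Compound 3 gives the largest of the three numbers, but its gap to compound 1 and its gap to compound 2 both lie within the usual scatter, so on this read-out the three compounds cannot be told apart. Going by the values given here, the only single-point step among them, a 1.3-fold lower number from compound 1 to compound 2 (0.12 log units; within the scatter), also stays within the scatter.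

Compound 4 `CC(C)(CCCC/C=C(\c1ccccc1)c1cccnc1)C(=O)O` is the next compound. Compared with compound 3, (the two compounds have the same atoms and bonds and differ only in configuration as drawn: 1 of 1 stereo elements differ; a double bond is drawn Z in compound 3 and E in compound 4). Among the compounds with values here, none of the measured steps touches the geometry of that double bond: the step from compound 1 to compound 2 changes the group on the saturated chain carbon, and compound 3 differs from the others in chain length as well as in geometry. Within the data shown here, there is therefore no measured step that bears directly on this change, and no ground for expecting a shift in either direction in this assay beyond the scatter.

Compound 4 is accordingly estimated at 38 nM, in the range 10 nM to 150 nM, which is expected to mean a step of no change at the digits printed from compound 3 to compound 4 (within the scatter), with the range kept wide to allow for the absence of a comparable measured step.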

Compound 4, half-maximal inhibitory concentration: 45 nM
Beside the measured number, compound 4's estimate is 1.2-fold (0.07 log units) below it; the measured number falls inside the stated range.
By their numbers in this assay, from the lowest: compounds 2, 1, 3 and 4 (each within the scatter of the next, the first and the last beyond it).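

The geometry of this double bond now has a direct test in this assay: a 1.2-fold higher number from compound 3 to compound 4 (0.07 log units; within the scatter). That step isolates the flip from Z to E, and it shows that at this position, on this chain, the flip alone leaves the number within the scatter, a clean reading because nothing else in the structure changes: the fact that compounds 3 and 4 differ only in the configuration as drawn. Going by these compounds alone, with the E geometry in place, the group on the saturated chain carbon can also be compared, and 2-carboxy-2-methylpropyl in place of 1-carboxy-1-methylethyl gives a 2.1-fold higher number from compound 2 to compound 4 (0.33 log units; beyond the scatter), the first step in this set to pass the scatter, whereas 2-carboxy-2-methylpropyl in place of 1-carboxy-2-methylprop-2-en-1-yl gives a 1.6-fold higher number from compound 1 to compound 4 (0.21 log units; within the scatter).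

The compounds shown leave open whether the same flip would stay this small with the 1-carboxy-1-methylethyl group of compound 2, since only one Z and E pair appears here. They also leave open how the number would respond to a still longer chain, or to an amide or an ester in place of the carboxylic acid.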